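The source may hold more compounds than are shown below. What is called first, only, known or untested is meant among the compounds shown, and "the series" means these compounds.

Compound 1 `Cc1c(C)c2c(c(C)c1O)CC[C@@](C)(CC[N+](C)(C)C)O2` is the stronger of the two measured compounds in a functional assay (brain) for inhibition, with Rattus norvegicus as the target (a higher number here means a weaker inhibitor, a lower number a stronger inhibitor), giving 2300 nM, whereas its carboxylic acid relative compound 2 `Cc1c(C)c2c(c(C)c1O)CC[C@@](C)(CC(=O)O)O2` gives 17000 nM, a change of a 7.4-fold higher number from compound 1 to compound 2 (0.87 log units; beyond the scatter). Compound 3 `Cc1c(C)c2c(c(C)c1O)CC[C@](C)(CC[N+](C)(C)C)O2` is its mirror-image partner: the two compounds have the same atoms and bonds and differ only in configuration as drawn: 1 of 1 stereo elements differ; a stereocentre at a saturated ring carbon is drawn S in compound 1 and R in compound 3. For the measured compounds named here, the only measured step swaps a group of atoms, so no measured step speaks to a change in configuration alone. Without such guidance, the step is expected to be a 1.3-fold higher number from compound 1 to compound 3 (0.12 log units; within the scatter), with a wide margin. Compound 3 is therefore estimated at 3000 nM, with a range from 1000 nM to 10000 nM.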

Compound 3, half-maximal inhibitory concentration: 2200 nM
The estimate for compound 3 lay 1.4-fold (0.13 log units) above the measured number; the range from low to high includes it.
By their numbers in this assay, from the lowest: compounds 3 and 1 (each within the scatter of the next); then compound 2.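

Changing this stereocentre at a saturated ring carbon from S to R in this assay gives a 1.0-fold lower number from compound 1 to compound 3 (0.02 log units; within the scatter), so the assay does not separate this mirror-image pair. The earlier step, a 7.4-fold higher number from compound 1 to compound 2 (0.87 log units; beyond the scatter), swapped a group of atoms, whereas this is the first comparison of configuration alone: the fact that compounds 1 and 3 differ only in the configuration as drawn

On these data alone, whether the configuration matters equally little for the carboxylic acid compound 2 remains open. So does the result of placing a primary amine or a longer chain on the core of compound 1.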